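Swapping the para substituent on the aryl ring of compound 3

This account rests on a few compounds, and the source may have more. Where it says the series, first, only, none or still open, it means among the compounds named here.

Measured compounds:
Compound 1 `Cc1cnc(Nc2ccc(C(=O)Nc3c(C)cccc3C)cc2)nc1-c1ccc(OC(F)(F)F)cc1` gives 1.3 nM in an assay on NIH3T3 cells for inhibition of Sonic hedgehog protein (Mus musculus), read by a luciferase reporter, with a stated time of 48 h; on this read-out lower numbers stand for stronger inhibition and higher numbers for weaker inhibition.
Compound 2 `Cc1cnc(Nc2ccc(C(=O)Nc3c(C)cccc3C)cc2)nc1-c1ccccc1OC(F)(F)F` gives only a limit of the assay, > 500 nM.
Compound 3 `Cc1cnc(Nc2ccc(C(=O)Nc3c(C)cccc3C)cc2)nc1-c1ccc(OC(F)(F)F)c(F)c1` gives 159 nM.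

Among the two compounds with a numeric read-out, compound 3 stands highest, and the nearest is compound 1 with a 120-fold higher number from compound 1 to compound 3 (2.09 log units; beyond the scatter). Compound 2 sits at the assay limit (the limit of > 500 nM in this assay, at which 1 of the 3 values shown sits). The step from compound 2 to compound 3 is an at least 3.1-fold lower number from compound 2 to compound 3 (0.49 log units; beyond the scatter).

Compound 4 `Cc1cnc(Nc2ccc(C(=O)Nc3c(C)cccc3C)cc2)nc1-c1ccc(C#N)cc1` differs from compound 3 by one change: 4-cyanophenyl in place of 3-fluoro-4-(trifluoromethoxy)phenyl on an aromatic carbon.

Among the compounds with values here, two measured steps bear on this. The step from compound 1 to compound 3 added a fluoro on the same ring and gave a 120-fold higher number from compound 1 to compound 3 (2.09 log units; beyond the scatter); compound 4 removes that fluoro again, so part of that loss is expected to be recovered. The step from compound 1 to compound 2 moved the trifluoromethoxy group and gave an at least 380-fold higher number from compound 1 to compound 2 (2.58 log units; beyond the scatter), showing that changes on this ring can matter greatly. Within the data shown here, no measured pair replaces the trifluoromethoxy group itself with a nitrile, so that part of the change is untested. Taken together, compound 4 is expected to give a lower number than compound 3 in this assay, with the step estimated as a 13-fold lower number from compound 3 to compound 4 (1.12 log units; beyond the scatter). The estimate for compound 4 is 12 nM, within the range 1.5 nM to 100 nM.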

Compound 4, half-maximal inhibitory concentration: 2.8 nM
Estimate against measurement, compound 4: 4.3-fold (0.63 log units) above; low and high end bracket the measured number.
By their numbers in this assay, from the lowest: compound 1; then compound 4; then compound 3. At a limit, above all of these: compound 2.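

In this assay, the trifluoromethoxy group turns out not to be essential on this ring: 4-cyanophenyl in place of 4-(trifluoromethoxy)phenyl gives a 2.2-fold higher number from compound 1 to compound 4 (0.33 log units; beyond the scatter), a modest step, though one beyond the usual scatter. Measured against the 3-fluoro-4-(trifluoromethoxy)phenyl ring, the same 4-cyanophenyl ring gives a 57-fold lower number from compound 3 to compound 4 (1.75 log units; beyond the scatter), so the aromatic carbon opposite the ring nitrogen keeps a low number with a quite different group on the attached ring, and the earlier large losses do not mean that any change there is costly. Measured against the 2-(trifluoromethoxy)phenyl ring, it gives an at least 170-fold lower number from compound 2 to compound 4 (2.25 log units; beyond the scatter), and that step is only a bound: the limit of > 500 nM in this assay, at which 1 of the 4 values shown sits.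

Going by these compounds, whether a fluoro added to the 4-cyanophenyl ring would cost as much as it did on the 4-(trifluoromethoxy)phenyl ring remains open, as does whether the nitrile would also be tolerated elsewhere on that ring. How an amine, a carboxylic acid or a longer chain would compare with the nitrile also stays unknown, and the compounds shown do not explain why the two groups give such similar results.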